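Changing one phenyl group on an amide-type nitrogen

This account rests on a few compounds, and the source may have more. Where it says the series, first, only, none or still open, it means among the compounds named here.

Three related compounds have been measured in a functional assay on THP-1 cells (Homo sapiens) for cytotoxicity, read by MTT assay, with a stated time of 24 h; a lower number here means a stronger inhibitor, a higher number a weaker inhibitor. Compound 1 `CCCCn1cc(Cn2nc(N)c3c(C(F)(F)F)cc(-c4ccccc4)nc32)nn1` gives 46.1 ug/mL. Compound 2 `Cc1ccc(-n2cc(Cn3nc(N)c4c(C(F)(F)F)cc(-c5ccccc5)nc43)nn2)cc1` gives 98.6 ug/mL. Compound 3 `Nc1nn(Cc2cn(CC(=O)Nc3ccc(F)cc3)nn2)c2nc(-c3ccccc3)cc(C(F)(F)F)c12` gives 49.6 ug/mL. Compound 3 lies within the scatter of both compound 1 and compound 2, so no order can be read between it and either of them. Going by the values given here, only one pair is separated beyond the scatter, and modestly: a 2.1-fold higher number from compound 1 to compound 2 (0.33 log units; beyond the scatter).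

The next compound, compound 4 `Nc1nn(Cc2cn(CC(=O)Nc3ccccc3Br)nn2)c2nc(-c3ccccc3)cc(C(F)(F)F)c12`, keeps all of compound 3 except one group, with 2-bromophenyl in place of 4-fluorophenyl on an amide-type nitrogen. Among the compounds with values here, no measured pair changes this group, so the data give no direct guide to this exchange. The nearest guides are broader exchanges in the side chain, and both stayed within the scatter: a 1.1-fold higher number from compound 1 to compound 3 (0.03 log units; within the scatter), and a 2.0-fold lower number from compound 2 to compound 3 (0.30 log units; within the scatter). Those small steps give no reason to expect a change in either direction in this assay, so the expectation is no step beyond the scatter. The expected step is a 1.0-fold higher number from compound 3 to compound 4 (0.00 log units; within the scatter). The estimate for compound 4 is 50 ug/mL, with an expected range from 25 ug/mL to 100 ug/mL.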

Compound 4, half-maximal inhibitory concentration: 95.3 ug/mL
The estimate for compound 4 lay 1.9-fold (0.28 log units) below the measured number; measured number inside the range.
By their numbers in this assay, from the lowest: compounds 1, 3, 4 and 2 (each within the scatter of the next, the first and the last beyond it).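

Going by these compounds alone, the first exchange at this amide-type nitrogen gives a 1.9-fold higher number from compound 3 to compound 4 (0.28 log units; within the scatter) in this assay, so swapping 4-fluorophenyl for 2-bromophenyl, two groups with the same count of heavy atoms, produces no readable difference here. The comparisons with the other side chains add a finer point: a 1.0-fold lower number from compound 2 to compound 4 (0.01 log units; within the scatter) places compound 4 level with the 4-methylphenyl compound, while a 2.1-fold higher number from compound 1 to compound 4 (0.32 log units; beyond the scatter) separates it modestly from the butyl compound, a separation that compound 3 does not show even though compound 3 and compound 4 cannot be told apart from each other. Nothing in the available data bears on what lies behind these numbers.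

This single exchange alters both the halogen and the name of the phenyl group that carries it, so the effect of fluorine against bromine cannot be separated from that of 4-substitution against 2-substitution. Compounds carrying 4-bromophenyl, 2-fluorophenyl or plain phenyl on this nitrogen would pull those two parts apart, and a phenyl ring bearing an amine or a carboxylic acid would test whether this position tolerates a very different kind of group.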